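Pyridazin-3-yl for pyrimidin-4-yl: what happens to the half-life?

A few compounds are considered here, and "the series" means these few. Any claim that something is new, unique, unknown or untested is made for them only; others in the source may bear on it.

Compound 1 `O=C(C1CCN(c2ccncn2)CC1)N1N=CC[C@H]1c1ccccc1` is the starting point for this step. In an ADME assay on cells (Hepatocyte, Homo sapiens) for metabolic stability (a higher number here means that the compound lasts longer, a lower number that the compound disappears faster), compound 1 gives a half-life of 3.3 h as its result. Among the measured compounds shown here, the only other measured compound is compound 2 `N#Cc1nccc(N2CCC(C(=O)N3N=CC[C@H]3c3cc(F)cc(F)c3)CC2)n1` which gives 2.1 h in this assay and these two numbers lie within the usual scatter of each other, so they cannot be told apart.

The compound still to be measured is compound 3 `O=C(C1CCN(c2cccnn2)CC1)N1N=CC[C@H]1c1ccccc1` which differs from compound 1 in a single place. It carries pyridazin-3-yl in place of pyrimidin-4-yl on an amine nitrogen in a ring and the two have the same atoms, joined differently.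

For the measured compounds named here, no two measured compounds differ in just one place, so the data give no direct measure of this kind of change. The expectation therefore stays anchored on compound 1 at 3.3 h with no shift beyond the scatter in either direction. The expected change is a 1.2-fold lower number from compound 1 to compound 3 (0.07 log units; within the scatter) and this estimate stays within the scatter. For compound 3 the expected half-life in this assay is 2.8 h with a range from 1.3 h to 6 h in this estimate.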

Compound 3, half-life: 2.32 h
Compound 3: middle estimate off by 1.2-fold (0.08 log units), on the high side; measured number inside the range.
By their numbers in this assay, from the lowest: compounds 2, 3 and 1 (each within the scatter of the next).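

Among the compounds shown here, replacing pyrimidin-4-yl with pyridazin-3-yl on an amine nitrogen in a ring gives the first direct reading of a single change at this position: in this assay the step is a 1.4-fold lower number from compound 1 to compound 3 (0.15 log units; within the scatter). The two rings have the same atoms, joined differently, and the same counts of hydrogen-bond donors and acceptors, so this step shows that this particular rearrangement leaves compound 1 and compound 3 impossible to tell apart by half-life. No measurement on these compounds offers an explanation for this result.

For the compounds shown here, this single step covers only one swap between two aromatic rings of the same size and atom count, so it leaves open whether a phenyl ring, a pyridin-2-yl ring or a small chain such as an acetyl group at the same place would shift the half-life beyond the scatter. Compound 2 differs from compound 1 in more than one place, so it cannot separate the effect of the group on the amine nitrogen from that of the other changes.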